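This account rests on a few compounds, and the source may have more. Where it says the series, first, only, none or still open, it means among the compounds named here.

Compound 1 `CN(C)CC1CCC/C(=C\c2ccc(OC(=O)/C=C/c3ccccc3)cc2)C1=O` and compound 2 `CN(C)CC1CCC/C(=C\c2ccc(OC(=O)/C=C/c3ccc(F)cc3)cc2)C1=O` share one core and differ only in one place, fluoro in place of hydrogen on an aromatic carbon. In a functional assay on P388 cells (Mus musculus) (on this read-out higher numbers stand for weaker inhibition and lower numbers for stronger inhibition), compound 1 gives 4020 nM, and compound 2 gives 4550 nM; the step of a 1.1-fold higher number from compound 1 to compound 2 (0.05 log units; within the scatter) leaves the two compounds within the scatter of each other, so compound 2 stands alongside compound 1 on the two numbers shown. Compound 3 `CN(C)CC1CCC/C(=C\c2ccc(OC(=O)/C=C/c3ccc(Cl)c(Cl)c3)cc2)C1=O` follows from compound 2 by the change (3,4-dichlorophenyl in place of 4-fluorophenyl on a double-bonded chain carbon bound to a double-bonded chain carbon). For the measured compounds named here, the only measured step that touches the same ring is the one from compound 1 to compound 2, and it was within the scatter, so there is no measured ground for a step beyond the scatter here either. The estimated step is a 1.0-fold lower number from compound 2 to compound 3 (0.00 log units; within the scatter). In this assay compound 3 is therefore expected to give about 4500 nM, between 1800 nM and 11000 nM.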

Compound 3, half-maximal inhibitory concentration: 4180 nM
Estimate against measurement, compound 3: 1.1-fold (0.03 log units) above, within the range that was stated.
By their numbers in this assay, from the lowest: compounds 1, 3 and 2 (each within the scatter of the next).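

In this assay the change reads as a 1.1-fold lower number from compound 2 to compound 3 (0.04 log units; within the scatter) and, against the unsubstituted phenyl, as a 1.0-fold higher number from compound 1 to compound 3 (0.02 log units; within the scatter), so both steps lie within the scatter. The earlier pair covered only a single fluoro in place of hydrogen, whereas compound 3 shows that 3,4-dichlorophenyl on a double-bonded chain carbon bound to a double-bonded chain carbon also stands alongside phenyl and 4-fluorophenyl. Nothing available explains why these three compounds stand so close together.

The compounds shown carry only hydrogen, fluorine or chlorine on this aromatic ring, so whether an amine, a carboxylic acid or a methoxy group there would give a step beyond the scatter stays open. From the compounds shown here alone, whether a longer chain elsewhere on the shared core would do so stays open as well.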